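The source may hold more compounds than are shown below. What is called first, only, known or untested is meant among the compounds shown, and "the series" means these compounds.

In a functional assay on MCF7 cells (Homo sapiens) for cytotoxicity, read by MTT assay, with a stated time of 48 h (a lower number here means a stronger inhibitor, a higher number a weaker inhibitor), compound 1 `CCCCCCCCNC(=O)[C@@H](NC(=O)c1nccc2ccccc12)[C@@H](C)O` gives 63200 nM. Compound 2 `CCCCCCCCCCCCNC(=O)[C@@H](NC(=O)c1ccco1)[C@@H](C)O` gives 67500 nM in this assay, which is the higher of the two numbers on record, though its gap to compound 1 lies within the scatter of repeated measurements, so the two compounds cannot be told apart on these data. Compound 3 `C/C=C/C=C/C(=O)N[C@H](C(=O)NCCCCCCCCCCCC)[C@@H](C)O` has not yet been measured. It differs from compound 2 in one place: penta-1,3-dien-1-yl in place of furan-2-yl on a carbonyl carbon. Among the compounds with values here, no measured pair shows what this exchange of acyl group does to the number, and both measured compounds sit at similar, weak values, so the step is expected to stay within the scatter and to have no clear direction, an expected 1.1-fold lower number from compound 2 to compound 3 (0.05 log units; within the scatter). For compound 3 the estimate in this assay is 60000 nM, with an expected range from 25000 nM to 150000 nM.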

Compound 3, half-maximal inhibitory concentration: 37100 nM
Compound 3: the middle estimate sits 1.6-fold (0.21 log units) above what was measured, within the range that was stated.
By their numbers in this assay, from the lowest: compounds 3, 1 and 2 (each within the scatter of the next).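

In this assay, the exchange of furan-2-yl for penta-1,3-dien-1-yl on a carbonyl carbon gives a 1.8-fold lower number from compound 2 to compound 3 (0.26 log units; within the scatter) and so stays within the scatter. Within the data shown here, this is the first direct comparison at this position, and it shows that an open chain with two double bonds can stand in place of a five-membered aromatic ring without a clear change in the number. The hetero atom and the hydrogen-bond acceptor of the furan-2-yl group are lost in the same step, and that loss also brings no clear change, while no measurement at hand explains the result.

As far as these compounds go, a saturated pentyl chain in the same place would show whether the double bonds matter at all, and an amine or a carboxylic acid at the end of that chain remains untested here. This single pair also cannot say whether the same exchange would read alike on compound 1, which carries a different chain on its other amide.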